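The source may report more compounds than this note shows. Statements on the series, on what has been measured and on what is new or still open speak of the compounds shown alone.

Compound 1 `O=C(Nc1ccccc1)Oc1ccc(Cl)cc1C(=O)Nc1ccc(F)cc1`: > 20000 nM (a limit)
Compound 2 `O=C(Nc1ccccc1)Oc1ccc(Cl)cc1C(=O)Nc1ccc(Br)cc1`: > 50000 nM (a limit)

In an ADME assay on HepG2 cells (Homo sapiens) for cytotoxicity, read by MTT assay (a higher number here means a weaker inhibitor, a lower number a stronger inhibitor), compound 2 gives > 50000 nM. This is a limit and not a number, so compound 2 has no exact place on the scale. Compound 1 gives > 20000 nM, which is also a limit.

The next compound, compound 3 `O=C(Nc1ccccc1)Oc1ccc(Cl)cc1C(=O)Nc1ccc(Cl)cc1`, differs from compound 2 at a single place: chloro in place of bromo on an aromatic carbon. It has chloro in place of bromo on an aromatic carbon, para to a large group. Compound 3 therefore keeps the shared core, with chloro where compound 1 has fluoro and compound 2 has bromo.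

For the measured compounds named here, only one measured step bears on this change, a step that the two limits leave unreadable from compound 1 to compound 2. That step gives no size to carry over, so no step beyond the scatter is expected in this assay, and no direction can be assigned. The estimated change is an at least 1.2-fold lower number from compound 2 to compound 3 (0.09 log units; that floor lies within the scatter). Compound 3 is expected at 40000 nM, with an estimated range from 15000 nM to 80000 nM.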

Compound 3, half-maximal inhibitory concentration: > 250000 nM
Compound 3: no number, only a limit (the forecaster's own chance of this, stated with the estimate: 80%); middle value at least 6.2-fold (0.79 log units) away from the limit.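

In this assay compound 3 gives > 250000 nM, which is a limit and not a number. For the compounds shown here, compound 1 and compound 2 also stand only as limits, so no step among compound 1, compound 2 and compound 3 can be read. The compounds shown leave open whether fluoro, chloro and bromo differ at this place, and at what concentration any of the three reaches half-maximal inhibition.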